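One more fluoro on a compound at the limit

The compounds below may be only part of what the source reports. "The series", "measured", "known", "first", "only" and "open" are said of these compounds alone.

In a functional assay on NCI/ADR-RES cells (Homo sapiens) for cytotoxicity (a lower number here means a stronger inhibitor of growth, a higher number a weaker inhibitor of growth), compound 1 (`COc1ccc(NS(=O)(=O)c2cc(F)c(F)c(F)c2F)cc1`) gives 400 nM and compound 2 (`COc1ccc(NS(=O)(=O)c2c(F)c(F)c(F)c(Br)c2F)cc1`) gives 190 nM as measured numbers. Compound 3 (`COc1ccc(NS(=O)(=O)c2c(F)c(F)cc(F)c2F)cc1`) stands at > 50000 nM as a limit of the assay and not a number. Only compound 3 sits there (the limit of > 50000 nM in this assay, at which 1 of the 3 values shown sits). Compound 4 (`COc1ccc(NS(=O)(=O)c2c(F)c(F)c(F)c(F)c2F)cc1`) puts fluoro in place of hydrogen on an aromatic carbon of compound 3, para to a large group (fluoro in place of hydrogen on an aromatic carbon). Compound 1 at 400 nM and compound 2 at 190 nM both hold a fluoro para to that large group, so compound 4 is expected to land close to them. The expected step (an at least 220-fold lower number from compound 3 to compound 4 (2.35 log units; beyond the scatter)) is a large one, well beyond the scatter, towards stronger growth inhibition. Compound 4 is estimated at 220 nM with an expected range from 70 nM to 800 nM in this test.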

Compound 4, concentration for 50% growth inhibition: 58 nM
Estimate against measurement, compound 4: 3.8-fold (0.58 log units) above; the measured number lies below the stated range.
By their numbers in this assay, from the lowest: compound 4; then compound 2; then compound 1. At a limit, above all of these: compound 3.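

Putting fluoro on this carbon, para to a large group, gives an at least 860-fold lower number from compound 3 to compound 4 (2.93 log units; beyond the scatter) and so decides between almost no growth inhibition and strong growth inhibition. Compound 3 stands at a limit of the assay and not at a number: the limit of > 50000 nM in this assay, at which 1 of the 4 values shown sits. Fluoro in place of hydrogen at another place gives a 6.9-fold lower number from compound 1 to compound 4 (0.84 log units; beyond the scatter) and fluoro in place of bromo gives a 3.3-fold lower number from compound 2 to compound 4 (0.52 log units; beyond the scatter) and both steps are modest beside the first one. What an amine or a nitrile at this position would give stays open, so the compounds shown cannot tell whether fluoro itself is needed here or any group would serve.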